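Swapping a ring amine for a hydroxycyclopentylamine

The source may hold more compounds than are shown below. What is called first, only, known or untested is meant among the compounds shown, and "the series" means these compounds.

Two related compounds have been measured in a functional assay on RKO cells (Homo sapiens) for antiproliferative activity, read by MTT assay, with a stated time of 5 days; a higher number here means a weaker inhibitor, a lower number a stronger inhibitor. Compound 1 `COc1cc[nH]c1/C=C1\C(=O)Nc2ccc([N+](=O)[O-])c(N3CC[C@H](O)C3)c21` gives 37 nM. Going by the values given here, compound 2 `COc1cc[nH]c1/C=C1\C(=O)Nc2ccc([N+](=O)[O-])c(N3CCCC(CO)C3)c21` gives 124 nM, the highest of the two numbers; the only step on record, a 3.4-fold higher number from compound 1 to compound 2 (0.53 log units; beyond the scatter), shows what replacing the smaller ring amine with the larger one did. Compound 3 `COc1cc[nH]c1/C=C1\C(=O)Nc2ccc([N+](=O)[O-])c(N[C@H]3CC[C@H](O)C3)c21` carries the change ((3-hydroxycyclopentyl)amino in place of 3-(hydroxymethyl)piperidin-1-yl on an aromatic carbon). Among the compounds with values here, the entering group is, like the group of compound 1, built on a five-membered ring with a hydroxyl sitting on that ring, and it is again smaller than the group it replaces, so the measured step bears on it in reverse: that step was modest, and a drop of roughly the same size, back toward the number of compound 1, is the expectation, although the switch from a ring nitrogen to an amine hydrogen linking the ring to the core has no measured counterpart here and widens the uncertainty. In this assay compound 3 is therefore expected to give about 50 nM, within a range of 15 nM to 170 nM, an estimated change of a 2.5-fold lower number from compound 2 to compound 3 (0.39 log units; beyond the scatter).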

Compound 3, half-maximal inhibitory concentration: 339 nM
Estimate against measurement, compound 3: 6.8-fold (0.83 log units) below; the measured number lies above the stated range.
By their numbers in this assay, from the lowest: compound 1; then compound 2; then compound 3.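

In this assay, the replacement of the six-membered ring by the smaller carbon-only ring gives a higher number, not a lower one (a 2.7-fold higher number from compound 2 to compound 3 (0.44 log units; beyond the scatter)), so a smaller group at this aromatic carbon, ortho to a nitro group, does not by itself restore the number of compound 1. The wider comparison is more telling: the groups of compound 1 and compound 3 both carry a hydroxyl on a five-membered ring, yet they are separated by the largest step in this set (a 9.2-fold higher number from compound 1 to compound 3 (0.96 log units; beyond the scatter)), so that shared feature does not keep the numbers together. In compound 3 the ring is joined to the core through an amino group, not through a ring nitrogen, but no measurement here explains why the number rises.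

The compounds shown leave open whether the rise follows the amino link, the carbon-only ring or the hydroxyl, and a plain cyclopentylamino group or a 3-hydroxypiperidin-1-yl group would help to separate these features. They also leave open how much depends on the two defined stereocentres of the (3-hydroxycyclopentyl)amino group, which its other stereoisomers would test.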